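Swapping the nitrile-bearing ring for an aminonitrophenyl ring

The source may report more compounds than this note shows. Statements on the series, on what has been measured and on what is new or still open speak of the compounds shown alone.

Compound 1 `N#Cc1ccc(Oc2cccc(NS(=O)(=O)c3cccc(C(F)(F)F)c3)c2)cc1` is a sulfonamide carrying a trifluoromethyl group; in a functional assay on PLC5 cells (Homo sapiens) for inhibition, read by MTT assay, with a stated time of 24 h (a lower number here means a stronger inhibitor, a higher number a weaker inhibitor), compound 1 gives 2200 nM. Among the values recorded, that is the only actual number. Compound 2 `N#Cc1ccc(Oc2cccc(NC(=O)c3ccccc3)c2)cc1`, an amide, reaches only a limit in this assay, > 15000 nM. Compound 3 `N#Cc1ccc(Oc2cccc(NS(=O)(=O)c3ccccc3)c2)cc1`, in which hydrogen stands in place of the trifluoromethyl, likewise reaches only a limit, > 15000 nM. Everything beyond compound 1 therefore sits at the limit of > 15000 nM in this assay, at which 2 of the 3 values shown sit. Going by the values given here, the one measured step, an at least 6.8-fold higher number from compound 1 to compound 3 (0.83 log units; beyond the scatter), concerns the trifluoromethyl group on the sulfonyl-bearing ring.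

Compound 4 `Nc1cc(Oc2cccc(NS(=O)(=O)c3cccc(C(F)(F)F)c3)c2)ccc1[N+](=O)[O-]` keeps that trifluoromethyl group and instead changes the ring on the ether oxygen: 3-amino-4-nitrophenyl in place of 4-cyanophenyl on an oxygen on an aromatic ring. Among the compounds with values here, no measured step touches this position, so the step from compound 3 gives no direct guide, and a change within the usual scatter is the plainest expectation. Compound 4 is therefore estimated at 2500 nM, between 700 nM and 9000 nM. For compound 4 the expected step is a 1.1-fold higher number from compound 1 to compound 4 (0.06 log units; within the scatter).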

Compound 4, half-maximal inhibitory concentration: 3900 nM
The estimate for compound 4 lay 1.6-fold (0.19 log units) below the measured number, within the range that was stated.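

Compound 4 is the first compound shown with anything other than 4-cyanophenyl on the ether oxygen, and in this assay the swap to 3-amino-4-nitrophenyl gives a 1.8-fold higher number from compound 1 to compound 4 (0.25 log units; within the scatter). With the trifluoromethyl group kept, the nitrile can therefore leave and an amino and a nitro group can enter with no change that stands out from repeat measurements, so this position accepts a quite different ring substitution. Compound 2 and compound 3 remain the only compounds shown that stop at a limit of the assay: the limit of > 15000 nM in this assay, at which 2 of the 4 values shown sit.

The amino and nitro groups enter together, so the compounds shown cannot tell what each does alone. On these data alone, it also stays open how a carboxylic acid or a methoxy group on this ring would read, and whether the same swap holds without the trifluoromethyl group.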